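The source may report more compounds than this note shows. Statements on the series, on what has been measured and on what is new or still open speak of the compounds shown alone.

Three measured compounds share a core and differ only in the aromatic group attached to it. Compound 1 `O=C(CCCCCCc1ccccc1)c1ncc(-c2ccccc2F)o1` gives 110 nM in an assay (Rattus norvegicus) for inhibition of Fatty-acid amide hydrolase 1 (Homo sapiens) (on this read-out lower numbers stand for stronger inhibition and higher numbers for weaker inhibition), compound 2 `O=C(CCCCCCc1ccccc1)c1ncc(-c2cccc(O)c2)o1` gives 50 nM, and compound 3 `NC(=O)c1ccc(-c2cnc(C(=O)CCCCCCc3ccccc3)o2)cc1` gives 10 nM. Compound 3 has the lowest number of the three: the steps of an 11-fold lower number from compound 1 to compound 3 (1.04 log units; beyond the scatter) and a 5.0-fold lower number from compound 2 to compound 3 (0.70 log units; beyond the scatter) are both beyond the scatter, so compound 3 is the strongest inhibitor among them. Compound 4 `NC(=O)c1cccc(-c2cnc(C(=O)CCCCCCc3ccccc3)o2)n1` differs from compound 3 by 6-carbamoylpyridin-2-yl in place of 4-carbamoylphenyl on an aromatic carbon. Among the measured compounds shown here, no measured step changes the ring itself in this way, so the earlier steps show only that this position accepts different groups. The step of a 1.5-fold higher number from compound 3 to compound 4 (0.18 log units; within the scatter) is expected to stay within the scatter. Compound 4 is estimated at 15 nM, with a range from 5 nM to 50 nM.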

Compound 4, inhibition constant: 1 nM
Estimate against measurement, compound 4: 15-fold (1.18 log units) above; measured number below the stated range.
By their numbers in this assay, from the lowest: compound 4; then compound 3; then compound 2; then compound 1.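

In this assay the ring change is not silent: 6-carbamoylpyridin-2-yl gives a 10-fold lower number from compound 3 to compound 4 (1.00 log units; beyond the scatter), so this position responds to the ring itself and not only to the group it carries. Compound 4 is the strongest inhibitor of the four, with a 50-fold lower number from compound 2 to compound 4 (1.70 log units; beyond the scatter) and a 110-fold lower number from compound 1 to compound 4 (2.04 log units; beyond the scatter). Nothing shown here explains this gain.

The change adds a ring nitrogen and also shifts the carbamoyl group, and the compounds shown do not separate the two. From the compounds shown here alone, whether 3-carbamoylphenyl or plain pyridin-2-yl would keep the gain stays open.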